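Moving the crotonamide around the benzyl ring

The source may report more compounds than this note shows. Statements on the series, on what has been measured and on what is new or still open speak of the compounds shown alone.

Among the measured compounds shown here, compound 1 `C/C=C/C(=O)Nc1ccc(Cn2nc(-c3ccc(Oc4ccccc4)cc3)cc2C(=O)OCC)cc1` and compound 2 `C=CC(=O)N1CCCC(n2nc(-c3ccc(Oc4ccccc4)cc3)cc2CO)C1` are the two measured members, both tested in a functional assay on Maver1 cells (Homo sapiens) for inhibition, read by luminescence and CellTiter-Glo, with a stated time of 72 h; a lower number here means a stronger inhibitor, a higher number a weaker inhibitor. For compound 1 the assay gives only a limit, > 60000 nM, rather than a number. Compound 2 gives 30500 nM in this assay. Compound 1 therefore stands at the limit of > 60000 nM in this assay, at which 1 of the 2 values shown sits, so its true potency is known only to be at or beyond the top of the measured window.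

Compound 3 `C/C=C/C(=O)Nc1cccc(Cn2nc(-c3ccc(Oc4ccccc4)cc3)cc2C(=O)OCC)c1` is not yet measured. It differs from compound 1 in one place: 3-(((prop-1-en-1-yl)carbonyl)amino)phenyl in place of 4-(((prop-1-en-1-yl)carbonyl)amino)phenyl on a saturated chain carbon bound to an aromatic nitrogen. The two structures share every atom and differ only in where the crotonamide-bearing substituent is attached to the phenyl.

For the measured compounds named here, no measured step between compound 1 and compound 3 exists, so the expectation rests on compound 1 alone. The step of a number no higher from compound 1 to compound 3 (the limit leaves the size open) is expected to be none beyond the usual scatter, since compound 1 already sits at the assay limit and the change is a repositioning rather than an addition. Compound 3 is therefore estimated at 60000 nM in this assay, with a likely range from 20000 nM to 200000 nM, and a strong chance that the assay again reports only a limit.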

Compound 3, half-maximal inhibitory concentration: 14200 nM
For compound 3 the middle estimate is 4.2-fold (0.63 log units) above the measured one; the measured number lies below the stated range.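

In this assay, putting 3-(((prop-1-en-1-yl)carbonyl)amino)phenyl in place of 4-(((prop-1-en-1-yl)carbonyl)amino)phenyl gives an at least 4.2-fold lower number from compound 1 to compound 3 (0.62 log units; beyond the scatter). This shows that the group on a saturated chain carbon bound to an aromatic nitrogen responds to where the crotonamide sits on the phenyl, even though no atom is added or lost. The value of compound 1 is a limit, so the true size of the step stays open and only its lower bound is known: the limit of > 60000 nM in this assay, at which 1 of the 3 values shown sits.

The compounds shown leave open whether the crotonamide itself contributes to the effect in this assay, a question that a plain propanamide or an acrylamide on the same phenyl of compound 3 would address. They also leave open how much the ethyl ester matters, since compound 3 offers a measured starting point for comparing it with a carboxylic acid or a primary amide at that place.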